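Swapping a Hydroxybenzoyl Arm for Trifluoromethyl

The source may hold more compounds than are shown below. What is called first, only, known or untested is meant among the compounds shown, and "the series" means these compounds.

Of the compounds shown here, three sharing one core have been tested in a functional assay (aorta) with Rattus norvegicus as the target; on this read-out higher numbers stand for higher potency (the scale is a negative logarithm) and lower numbers for lower potency. Compound 1 `CC1(C)C=C(n2ccccc2=O)c2cc(C(=O)c3ccc(O)cc3)ccc2O1` gives 6.65. Compound 2 `CC1(C)C=C(n2ccccc2=O)c2cc(C(=O)c3ccc([N+](=O)[O-])cc3)ccc2O1` gives 6.2, and compound 3 `CC1(C)C=C(n2ccccc2=O)c2cc(C(=O)c3ccccc3C(F)(F)F)ccc2O1` gives 6.76. Compound 1 stands second of the three: compound 3 lies a number 0.11 log units higher from compound 1 to compound 3 (within the scatter), a gap within the usual scatter, while compound 2 lies a number 0.45 log units lower from compound 1 to compound 2 (beyond the scatter).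

Compound 4 `CC1(C)C=C(n2ccccc2=O)c2cc(C(F)(F)F)ccc2O1` has not been measured. It differs from compound 1 in one place: trifluoromethyl in place of (4-hydroxyphenyl)carbonyl on an aromatic carbon. The whole (4-hydroxyphenyl)carbonyl arm is gone and a small trifluoromethyl sits in its stead on the core.

The two measured steps from compound 1 only vary the aromatic ring at the far end of that arm, keeping the carbonyl in place, and both stayed modest: a number 0.45 log units lower from compound 1 to compound 2 (beyond the scatter) and a number 0.11 log units higher from compound 1 to compound 3 (within the scatter). Neither step removes the arm itself, so no measured comparison bears directly on compound 4. The narrow spread of the three values suggests the arm tolerates change, yet its full loss is a larger move than anything tested.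

Compound 4 is therefore expected to land somewhat lower, at 5.9, within a wide band from 5.1 to 6.7, a step estimated as a number 0.75 log units lower from compound 1 to compound 4 (beyond the scatter).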

Compound 4, logarithm of the reciprocal of the active concentration, log(1/C): 7.61
Compound 4: the middle estimate sits 1.71 log units below what was measured; measured number outside the range, above it.
By their numbers in this assay, from the lowest: compound 2; then compounds 1 and 3 (each within the scatter of the next); then compound 4.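

In this assay, replacing the whole (4-hydroxyphenyl)carbonyl arm with trifluoromethyl on the same aromatic carbon gives a number 0.96 log units higher from compound 1 to compound 4 (beyond the scatter). The earlier compounds shown here changed only the ring at the far end of the arm and kept the carbonyl, whereas this result shows that potency at this position does not depend on the arm at all: its ring, its carbonyl and its hydrogen-bond donor can all leave without any loss in this assay. Why potency rises with this change cannot be told from these compounds, as nothing measured here speaks to the cause.

The compounds shown do not separate the loss of the arm from the arrival of trifluoromethyl: a plain hydrogen on that aromatic carbon would test this directly, while a chlorine, a nitrile or a methyl there would show whether other groups without a ring behave like trifluoromethyl. Also open, as far as these compounds go, is where an acetyl group, which keeps the carbonyl but has no aromatic ring, would fall relative to compound 1 and compound 4.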